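Varying the group on the ring nitrogen: compound 3

This account rests on a few compounds, and the source may have more. Where it says the series, first, only, none or still open, it means among the compounds named here.

The compounds share one core and differ only in the group on the aromatic nitrogen of the five-membered ring. In an assay on isolated protein for inhibition of STE20-like serine/threonine-protein kinase (Homo sapiens), read by thermal shift assay, tested at 10 uM (a higher number here means that the compound stabilises the target more against heat, a lower number that the compound stabilises the target less), compound 1 `Cc1ccc(-n2nc(C(C)(C)C)cc2NC(=O)Nc2cc(F)cc(F)c2)cc1` gives 2.8 degrees C, while compound 2 `Cn1nc(C(C)(C)C)cc1NC(=O)Nc1cc(F)cc(F)c1` gives 1.2 degrees C. The step of a number 1.6 degrees C lower from compound 1 to compound 2 (beyond the scatter) lies beyond the scatter. Compound 2 thus stands lowest of the two numbers in this assay, its nearest neighbour being compound 1. Compound 3 `CC(C)(C)c1cc(NC(=O)Nc2cc(F)cc(F)c2)n(C(C)(C)C)n1` is the next step: tert-butyl in place of methyl on an aromatic nitrogen, next to the ring nitrogen and next to the ring atom that bears a large group. Among the compounds with values here, only the step from compound 1 to compound 2 bears on this, and it concerns a different group leaving the same nitrogen, so it guides direction only loosely. A modest rise in this assay is expected for compound 3, namely a number 0.60 degrees C higher from compound 2 to compound 3 (within the scatter), though it may stay within the scatter. Compound 3 is therefore estimated at 1.8 degrees C, with a range of 0.5 degrees C to 3.2 degrees C in this assay.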

Compound 3, shift of the target's melting temperature: 0.2 degrees C
Estimate against measurement, compound 3: 1.6 degrees C above; the measured number lies below the stated range.
By their numbers in this assay, from the lowest: compounds 3 and 2 (each within the scatter of the next); then compound 1.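

Replacing methyl with tert-butyl on the aromatic nitrogen gives a number 1.0 degrees C lower from compound 2 to compound 3 (within the scatter) in this assay, so these two groups cannot be told apart at this position, and the larger group without a ring brings no gain over methyl. Replacing 4-methylphenyl with tert-butyl gives a number 2.6 degrees C lower from compound 1 to compound 3 (beyond the scatter), so among the three groups shown, only 4-methylphenyl stands apart, and it is also the only one that carries a ring. No measured evidence bears on why these numbers fall as they do.

On these data alone, it remains open whether the ring itself or its methyl group goes with the higher number of compound 1. Phenyl, benzyl or pyridyl on this nitrogen would test that directly.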